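Bromo Substitution on a Shared Core in Two Series

The compounds below may be only part of what the source reports. "The series", "measured", "known", "first", "only" and "open" are said of these compounds alone.

The study concerns three measured compounds and one still to be measured in a functional assay on cells (Cancer cell lines, Homo sapiens) for cytotoxicity, read by sulforhodamine B assay, with a stated time of 48 h; on this read-out lower numbers stand for stronger inhibition of growth and higher numbers for weaker inhibition of growth. Compound 1 `COc1ccc(C2=NN(C3=NC(=O)/C(=C4\C(=O)Nc5ccccc54)S3)C(c3ccc(Cl)cc3)C2)cc1` gives 100000 nM in this assay. Compound 2 `COc1ccc(C2=NN(C3=NC(=O)/C(=C4\C(=O)Nc5ccc(Br)cc54)S3)C(c3ccc(Cl)cc3)C2)cc1` gives 7440 nM in this assay, and the step of a 13-fold lower number from compound 1 to compound 2 (1.13 log units; beyond the scatter) goes with the change (bromo in place of hydrogen on an aromatic carbon). Compound 3 `CN(C)c1ccc(C2CC(c3ccccc3)=NN2C2=NC(=O)/C(=C3\C(=O)Nc4ccccc43)S2)cc1` gives 35300 nM in this assay; its number stands second highest of the three, and its gaps to compound 1 and to compound 2 both lie beyond the scatter. The difference between the core of compound 1 and the core of compound 3 is not broken down here.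

Compound 4 `CN(C)c1ccc(C2CC(c3ccccc3)=NN2C2=NC(=O)/C(=C3\C(=O)Nc4ccc(Br)cc43)S2)cc1` has not yet been measured in this assay. It differs from compound 3 by bromo in place of hydrogen on an aromatic carbon, which is the same change as that from compound 1 to compound 2, at a place described in the same words. Because the earlier step of a 13-fold lower number from compound 1 to compound 2 (1.13 log units; beyond the scatter) was large, a step in the same direction is expected here, though somewhat smaller, since the two cores differ in a way not broken down and the change has been seen only once. The step from compound 3 to compound 4 is therefore estimated as a 7.8-fold lower number from compound 3 to compound 4 (0.89 log units; beyond the scatter). Compound 4 is expected to give about 4500 nM in this assay. For compound 4 the likely range is estimated to run from 1500 nM to 15000 nM.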

Compound 4, concentration for total growth inhibition: 420 nM
Compound 4: the middle estimate sits 11-fold (1.03 log units) above what was measured, outside the stated range (below it).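

In this assay the bromo group in place of hydrogen again goes with a lower number on the second core, the new step being an 84-fold lower number from compound 3 to compound 4 (1.92 log units; beyond the scatter). The direction of the change therefore carried over from the core of compound 1 to the core of compound 3, but its size did not, so the step seen on one core cannot be applied as a fixed amount to the other: the same change on two cores in this assay, a 13-fold lower number (1.13 log units; beyond the scatter) from compound 1 to compound 2 and an 84-fold lower number (1.92 log units; beyond the scatter) from compound 3 to compound 4, 6.3-fold (0.80 log units) apart, beyond the scatter of two such steps. The two pairs do not show which feature of the cores goes with the larger step, and they say nothing about how the change would behave on any further core.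

The compounds shown leave open whether fluoro, nitro or a carboxylic acid on the same aromatic carbon would go with a step like that of bromo, as only hydrogen and bromo appear there. They also leave open which of the groups that separate the two cores, the methoxy and chloro groups of compound 1 or the dimethylamino group of compound 3, goes with the difference in step size.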